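A Swap on the Amine Nitrogen of Compound 1

The compounds below may be only part of what the source reports. "The series", "measured", "known", "first", "only" and "open" are said of these compounds alone.

In a functional assay on HCT-116 cells (Homo sapiens) for cytotoxicity, read by MTT assay (a higher number here means a weaker inhibitor, a lower number a stronger inhibitor), compound 1 `CSc1nc(NCc2ccc(C(=O)Nc3ccccc3N)cc2)n[nH]1` gives 600 nM, the highest of three numbers. Compound 3 `Nc1ccccc1NC(=O)c1ccc(CSc2nnc(-c3ccccc3)o2)cc1` at 400 nM lies within the scatter of compound 1, while compound 2 `Nc1ccccc1NC(=O)c1ccc(CNc2nc3cc(Cl)ccc3o2)cc1` at 200 nM stands lower by more than the scatter. Compound 1 therefore sits at the weaker end of this small set, level with compound 3.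

Compound 4 `Nc1ccccc1NC(=O)c1ccc(CNc2ncc(Br)s2)cc1` keeps the rest of compound 1 but carries 5-bromo-1,3-thiazol-2-yl in place of 5-(methylsulfanyl)-1H-1,2,4-triazol-3-yl on an amine nitrogen. Among the measured compounds shown here, no measured pair shows this exchange on its own, so any forecast is rough. Compound 2 also has a different group on an amine nitrogen, and its 200 nM suggests that such a change can give a lower number. In this assay a small expected move toward a lower number, about the size of the scatter, is a 2.0-fold lower number from compound 1 to compound 4 (0.30 log units; within the scatter). For compound 4 the estimated value is 300 nM, with an expected range from 100 nM to 900 nM.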

Compound 4, half-maximal inhibitory concentration: 400 nM
Beside the measured number, compound 4's estimate is 1.3-fold (0.12 log units) below it; measured number inside the range.
By their numbers in this assay, from the lowest: compounds 2, 3, 4 and 1 (each within the scatter of the next, the first and the last beyond it).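

In this assay, the exchange on this amine nitrogen gives a 1.5-fold lower number from compound 1 to compound 4 (0.18 log units; within the scatter) and so stays within the usual scatter. Among the compounds shown here, this is the first measured pair that differs in this one place, and it shows that the number holds level when one five-membered aromatic ring replaces another. That holds even though the leaving 5-(methylsulfanyl)-1H-1,2,4-triazol-3-yl has 1 hydrogen-bond donor, the entering 5-bromo-1,3-thiazol-2-yl has 0 hydrogen-bond donors, and bromine enters the molecule.

The compounds shown leave open what a plain 1,3-thiazol-2-yl without the bromine, a simple phenyl or a carboxylic acid on the ring would give at this nitrogen. Nothing measured here accounts for the number holding level across this exchange.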